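This account rests on a few compounds, and the source may have more. Where it says the series, first, only, none or still open, it means among the compounds named here.

Measured compounds:
compound 1 `CCN(CC)S(=O)(=O)c1ccc(S(=O)(=O)N2CCC[C@@H](C(=O)N[C@@H]3CCN(C(=O)OC(C)(C)C)C3)C2)cc1`: 200 nM
compound 2 `CCOC(=O)[C@H]1CCN(S(=O)(=O)c2ccc(S(=O)(=O)N(CC)CC)cc2)C1`: 29200 nM

In a functional assay on MIA PaCa-2 cells (Homo sapiens) for inhibition, read by MTT assay, with a stated time of 7 days (a higher number here means a weaker inhibitor, a lower number a stronger inhibitor), compound 1 gives 200 nM, the lowest of the two numbers here, while compound 2 gives 29200 nM, a gap that lies well beyond the scatter. Compound 3 `CCN(CC)S(=O)(=O)c1ccc(S(=O)(=O)N2CCC[C@@H](C(=O)NC3CN(S(C)(=O)=O)C3)C2)cc1` has not yet been measured. It differs from compound 1 by 1-(methylsulfonyl)azetidin-3-yl in place of 1-(tert-butoxycarbonyl)pyrrolidin-3-yl on an amide-type nitrogen. Within the data shown here, no step between measured compounds shows what such a change does, so only a modest shift in this assay is expected, most likely toward a weaker number but possibly within the scatter. The estimated step is a 2.0-fold higher number from compound 1 to compound 3 (0.30 log units; within the scatter). Compound 3 is accordingly expected to give about 400 nM, between 100 nM and 1600 nM.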

Compound 3, half-maximal inhibitory concentration: 2500 nM
Compound 3: the middle estimate sits 6.3-fold (0.80 log units) below what was measured; measured number outside the range, above it.
By their numbers in this assay, from the lowest: compound 1; then compound 3; then compound 2.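

The amide-type nitrogen turns out to be a place where the substituent matters in this assay: 1-(methylsulfonyl)azetidin-3-yl in place of 1-(tert-butoxycarbonyl)pyrrolidin-3-yl brings a 13-fold higher number from compound 1 to compound 3 (1.10 log units; beyond the scatter), a large step. The earlier compounds shown here offered no such one-place comparison. No measurement here accounts for the size of this step. The compounds shown leave open whether the step goes with the change of ring or with the change from tert-butoxycarbonyl to methylsulfonyl; 1-(methylsulfonyl)pyrrolidin-3-yl or 1-(tert-butoxycarbonyl)azetidin-3-yl on the same nitrogen would separate the two.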